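The compounds below may be only part of what the source reports. "The series", "measured", "known", "first", "only" and "open" are said of these compounds alone.

Compound 1 `COc1ccc(-c2cc(/C=C/C(=O)c3ccc(N)cc3)[nH]n2)cc1`: 97%
Compound 2 `COc1ccc(C(=O)/C=C/c2cc(-c3cc(OC)c(OC)c(OC)c3)n[nH]2)cc1`: 99%
Compound 3 `COc1cc(-c2cc(/C=C/C(=O)c3ccc(F)c(F)c3)[nH]n2)cc(OC)c1OC`: 97%

All three were tested in a functional assay on SF-539 cells (Homo sapiens) for cytotoxicity, read by sulforhodamine B assay, with a stated time of 48 h, tested at 0.1 uM; a higher number here means a weaker effect of the compound at the concentration tested, a lower number a stronger effect. On these numbers compound 1 stands level with compound 3 at the digits printed, the two together being the lowest of the three, and compound 2 lies within the scatter of both, so none of the three can be told apart. Among the compounds with values here, the only step in which a single change is made, a number 2 percentage points lower from compound 2 to compound 3 (within the scatter), puts a 3,4-difluorophenyl in place of a 4-methoxyphenyl on the carbonyl carbon and stays within the scatter.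

The unmeasured compound 4 `COc1ccc(-c2cc(/C=C/C(=O)c3ccc(N)cc3)[nH]n2)cc1OC` differs from compound 1 by methoxy in place of hydrogen on an aromatic carbon, ortho to a methoxy group and meta to a large group. Within the data shown here, no measured step touches this part of the structure, so the step from compound 2 to compound 3 gives no direct guide. What the numbers do show is that every compound tested gives a reading close to the top of the scale, and compound 4 is therefore expected to do the same, with a step of no change at the digits printed from compound 1 to compound 4 (within the scatter) that stays within the scatter. The estimate for compound 4 in this assay is 97%, within 88% to 104%.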

Compound 4, a percentage reported as activity, at one concentration (the size of the read-out at that concentration, not a potency): 97%
The estimate for compound 4 equals the measured number at the digits printed; low and high end bracket the measured number.
By their numbers in this assay, from the lowest: compounds 1, 3, 4 and 2 (each within the scatter of the next).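

The pair of compound 1 and compound 4 offers a reading on a part of the structure that the earlier step did not touch: in this assay, methoxy in place of hydrogen on an aromatic carbon, ortho to a methoxy group and meta to a large group, gives no change at the digits printed from compound 1 to compound 4 (within the scatter). This position therefore takes a second methoxy group with no visible shift in the reading, but both compounds sit near the top of the scale, so the result cannot show whether the change would matter in a setting where the compounds have a clear effect. Nothing available bears on why the reading stays the same.

On these data alone, it remains open whether a different group at this position, such as a hydroxyl, a chlorine or a longer ethoxy chain, would move the reading beyond the usual scatter. As far as these compounds go, it is also open whether compound 1 and compound 4 would separate at a concentration where the readings fall well away from the top of the scale.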